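This account rests on a few compounds, and the source may have more. Where it says the series, first, only, none or still open, it means among the compounds named here.

In a functional assay on P388 cells (Mus musculus) for antiproliferative activity, with a stated time of 72 h (on this read-out lower numbers stand for stronger inhibition and higher numbers for weaker inhibition), compound 2 `CSc1cnc2ccccc2c1SCC#CCO` gives 3.1 ug/mL, the second highest of the three numbers recorded. Compound 1 `OCC#CCSc1cnc2ccccc2c1Cl` gives 2.4 ug/mL, and the two lie within the scatter of each other; compound 3 `ClCC#CCSc1cnc2ccccc2c1Cl` gives 13.4 ug/mL, beyond it. Compound 4 `CCOC(=O)OCC#CCSc1c(SC)cnc2ccccc12` differs from compound 2 by ethoxycarbonyl in place of hydrogen on an oxygen on a saturated carbon. Among the measured compounds shown here, only one measured step touches the same part of the molecule: a 5.6-fold higher number from compound 1 to compound 3 (0.75 log units; beyond the scatter), an alteration of the hydroxy group on the chain. Converting hydroxy to (ethoxycarbonyl)oxy is a different alteration, yet the one precedent shows that changing the hydroxy raised the number. Compound 4 is therefore expected to show a modest rise, a 1.8-fold higher number from compound 2 to compound 4 (0.25 log units; within the scatter). The value of compound 4 in this assay is estimated at 5.5 ug/mL, within a range from 2.5 ug/mL to 13 ug/mL.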

Compound 4, concentration for 50% inhibition: 34.7 ug/mL
Estimate against measurement, compound 4: 6.3-fold (0.80 log units) below; measured number above the stated range.
By their numbers in this assay, from the lowest: compounds 1 and 2 (each within the scatter of the next); then compound 3; then compound 4.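

In this assay, ethoxycarbonyl in place of hydrogen on the oxygen gives an 11-fold higher number from compound 2 to compound 4 (1.05 log units; beyond the scatter), a large step. With the earlier change of chloro in place of hydroxy, which gave a 5.6-fold higher number from compound 1 to compound 3 (0.75 log units; beyond the scatter), this makes two changes at this end of the chain, and both raise the number. No measurement given here accounts for the rise. The compounds shown leave open whether any group on this oxygen raises the number this far, or only ethoxycarbonyl. An acetyl group or a methyl ether on the same oxygen, or an amine in place of the hydroxy, would bear on that.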